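Compound 3 and its 3,4-dihydroxyphenyl counterpart, compound 4

The source may hold more compounds than are shown below. What is called first, only, known or untested is meant among the compounds shown, and "the series" means these compounds.

In a functional assay on HeLa cells (Homo sapiens) for inhibition, read by CCK-8 assay, with a stated time of 48 h (a higher number here means a weaker inhibitor, a lower number a stronger inhibitor), compound 3 `COc1ccc(Oc2ccccc2-c2ccsc2S(=O)(=O)N2CCN(C(=S)Nc3ccc(Cl)cc3)CC2)cc1OC` gives only the limit > 50000 nM and no number. The change to compound 4 `O=S(=O)(c1sccc1-c1ccccc1Oc1ccc(O)c(O)c1)N1CCN(C(=S)Nc2ccc(Cl)cc2)CC1` is 3,4-dihydroxyphenyl in place of 3,4-dimethoxyphenyl on an oxygen on an aromatic ring and puts 3,4-dihydroxyphenyl in place of 3,4-dimethoxyphenyl on an oxygen on an aromatic ring. Within the data shown here, no measured step covers this change. The only one is an at least 1.3-fold lower number from compound 1 to compound 2 (0.13 log units; that floor lies within the scatter) and it concerns another group. Compound 1 `O=C(Nc1cccc([N+](=O)[O-])c1)N1CCN(S(=O)(=O)c2sccc2-c2ccccc2Oc2ccc(O)c(O)c2)CC1` carries the 3,4-dihydroxyphenyl group and gives only the limit > 20000 nM as its entry. Compound 2 `O=C(Nc1ccc(F)cc1)N1CCN(S(=O)(=O)c2sccc2-c2ccccc2Oc2ccc(O)c(O)c2)CC1` carries the same group and reads 14800 nM as a true number. On that guide a lower number is expected in this assay with an at least 3.5-fold lower number from compound 3 to compound 4 (0.55 log units; beyond the scatter) as the estimated step. For compound 4 the estimate is 14000 nM with an expected range from 5000 nM to 40000 nM for the measurement.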

Compound 4, half-maximal inhibitory concentration: > 50000 nM
Compound 4 was reported as a limit (the forecaster's own chance of this, stated with the estimate: 30%); middle value at least 3.5-fold (0.55 log units) from the limit.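

In this assay compound 4 gives > 50000 nM as a limit and not a number. Among these compounds, the one readable step is an at least 3.3-fold higher number from compound 2 to compound 4 (0.52 log units; beyond the scatter) with the group on the amine nitrogen in the ring exchanged, while the steps to compound 4 from compound 3 and from compound 1 cannot be read. The 3,4-dihydroxyphenyl group therefore does not bring compound 4 to a true number, and compound 3 and compound 4 share one limit: the limit of > 50000 nM in this assay, at which 2 of the 4 values shown sit. On these data alone, whether an amine or a carboxylic acid in place of the two hydroxyl groups would give a true number remains open.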